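This account rests on a few compounds, and the source may have more. Where it says the series, first, only, none or still open, it means among the compounds named here.

Of the compounds shown here, three from one series have been tested in a functional assay, read by Griess assay, with a stated time of 150 min, tested at 50 ug/mL; a lower number here means a weaker effect, a higher number a stronger effect of the compound at the concentration tested. Compound 2, with the structure `Cc1ccc(C2CNN=C2S(=O)(=O)CC2=NCCS2)cc1`, gives 43.1%. Compound 3, with the structure `Cc1ccc(C2CNN=C2S(=O)(=O)CC2=NCCO2)cc1`, gives 45.9%. These two share a core and differ in a single place: a group of 5 heavy atoms (3 carbon, 1 nitrogen, 1 sulfur; one five-membered non-aromatic ring with 2 hetero atoms) in place of a group of 5 heavy atoms (3 carbon, 1 nitrogen, 1 oxygen; one five-membered non-aromatic ring with 2 hetero atoms), on a saturated chain carbon bound to a sulfonyl sulfur. The measured outcome of that change is a number 2.8 percentage points lower from compound 3 to compound 2 (within the scatter), so the two compounds show effects of essentially the same size.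

Compound 1, with the structure `O=S(=O)(CC1=NCCO1)C1C(c2ccc(Cl)cc2)=NOC1c1ccc(Cl)cc1`, is built on a different core; how that core differs from the core of compound 3 is not broken down here. In this assay compound 1 is reported as "not active" (no number reported), without any number attached.

Compound 4, with the structure `O=S(=O)(CC1=NCCS1)C1C(c2ccc(Cl)cc2)=NOC1c1ccc(Cl)cc1`, has not yet been measured. It relates to compound 1 in the same way that compound 2 relates to compound 3: a group of 5 heavy atoms (3 carbon, 1 nitrogen, 1 sulfur; one five-membered non-aromatic ring with 2 hetero atoms) in place of a group of 5 heavy atoms (3 carbon, 1 nitrogen, 1 oxygen; one five-membered non-aromatic ring with 2 hetero atoms), on a saturated chain carbon bound to a sulfonyl sulfur. The place of the change is the same in both pairs, so this is the same change applied to a second core.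

Because a number 2.8 percentage points lower from compound 3 to compound 2 (within the scatter) shows that the change left the effect where it was on the first core, and because compound 1 gives "not active" (no number reported), compound 4 is expected to stay weak as well. The estimate for compound 4 in this assay is 10%, with an expected range from 0% to 25%, and it may well again be reported only as not active.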

Compound 4, a percentage reported as activity, at one concentration (the size of the read-out at that concentration, not a potency): "not active" (no number reported)
No number was reported for compound 4, so the estimate cannot be set against anything.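

In this assay, among the compounds shown here, compound 1 gives "not active" (no number reported) and compound 4 gives "not active" (no number reported), so no step between these two compounds can be read. Nothing available here bears on this result. What these two compounds leave open is whether the exchange of the sulfur-containing ring group for the oxygen-containing one changes the effect at all on the core of compound 1.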